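The compounds below may be only part of what the source reports. "The series", "measured", "known", "first", "only" and "open" are said of these compounds alone.

Measured compounds in a functional assay on the whole organism (Tail, strain ICR) with Mus musculus as the target, in the tail flick test, with a stated time of 60 min, at a dose of 25 umol/kg by the oral route; on this read-out higher numbers stand for a stronger effect at the one dose given and lower numbers for a weaker effect:

- compound 1 `C[C@H](NC(=O)CN(c1ncnc2c1ncn2C1CCCCO1)C1CC1)C(=O)OCc1ccccc1`: 53%
- compound 2 `O=C(O)C[C@H](NC(=O)CN(c1nc(Cl)nc2[nH]cnc12)C1CC1)C(=O)O`: 38.9%

Going by the values given here, compound 2 gives the lowest of the two numbers in this assay; the only comparison point is compound 1, which stands higher by a margin beyond the usual scatter. The two measured compounds differ in several places at once, so no single-change step can be read off between them, and the pair tells nothing about the side-chain change considered here.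

The untested compound 3 `NC(=O)C[C@H](NC(=O)CN(c1nc(Cl)nc2[nH]cnc12)C1CC1)C(=O)O` differs from compound 2 in one place: amino in place of hydroxy on a carbonyl carbon. In the wider reading this is carboxy to carbamoyl on the side chain. Among the compounds with values here, no measured pair shows what such a change does in this assay. The expected step of a number 1.1 percentage points higher from compound 2 to compound 3 (within the scatter) is therefore small, with no preferred direction beyond the scatter. For compound 3 the estimate in this assay is 40%, expected to fall between 20% and 60%.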

Compound 3, a percentage reported as activity, at one dose (the size of the read-out at that dose, not a potency): 43.1%
Estimate against measurement, compound 3: 3.1 percentage points below; low and high end bracket the measured number.
By their numbers in this assay, from the lowest: compounds 2, 3 and 1 (each within the scatter of the next, the first and the last beyond it).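

Amino in place of hydroxy on a carbonyl carbon gives a number 4.2 percentage points higher from compound 2 to compound 3 (within the scatter) in this assay, so carboxy to carbamoyl at this place on the side chain produces no step that can be told from the scatter. Going by these compounds alone, this is the first single-change step, which the earlier pair, differing in several places at once, could not provide. At the one dose given, the carboxymethyl and carbamoylmethyl forms of the side chain cannot be told apart, and nothing available bears on why the read-out holds across this change.

On these data alone, whether a methyl ester at this carbonyl carbon, or a longer chain carrying the carboxylic acid, would move the read-out beyond the scatter stays open. As far as these compounds go, it also stays open which of the several differences separates compound 1 from compound 2.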